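Methylthio, Methylsulfinyl, Methylsulfonyl on a Shared Core

The source may report more compounds than this note shows. Statements on the series, on what has been measured and on what is new or still open speak of the compounds shown alone.

Measured compounds:
Compound 1 `CSc1ccc(-c2nc3c(Sc4ccccc4)ncnc3n2C)cc1`: 5%
Compound 2 `Cn1c(-c2ccc([S+](C)[O-])cc2)nc2c(Sc3ccccc3)ncnc21`: 4%

Going by the values given here, in an assay on isolated protein for inhibition of RAC-alpha serine/threonine-protein kinase (Homo sapiens), tested at 30 uM (a lower number here means less inhibition, a higher number more inhibition at the concentration tested (going by the name of the read-out)), compound 2 gives 4%, the lower of the two numbers seen, with compound 1 the only neighbour and within the scatter of it. Compound 3 `Cn1c(-c2ccc(S(C)(=O)=O)cc2)nc2c(Sc3ccccc3)ncnc21` differs from compound 2 by a group of 4 heavy atoms (1 carbon, 2 oxygen, 1 sulfur; no ring) in place of a group of 3 heavy atoms (1 carbon, 1 oxygen, 1 sulfur; no ring), on an aromatic carbon. Among the compounds with values here, the one measured step that bears on this change is the earlier move on the same aromatic carbon, a number 1 percentage points lower from compound 1 to compound 2 (within the scatter), which stayed within the scatter; both measured compounds sit at the bottom of the read-out. Within the data shown here, no step shows the methylsulfonyl group itself. On the numbers at hand, the step to compound 3 in this assay is expected to be a number 1 percentage points higher from compound 2 to compound 3 (within the scatter), that is none beyond the scatter. Compound 3 is therefore estimated to give 5% in this assay, within the range 0% to 15%.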

Compound 3, a percentage reported as inhibition, at one concentration (the size of the read-out at that concentration, not a potency): 14%
For compound 3 the middle estimate is 9 percentage points below the measured one; measured number inside the range.
By their numbers in this assay, from the lowest: compounds 2, 1 and 3 (each within the scatter of the next).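

With methylsulfonyl on the aromatic carbon para to a large group, this assay gives a number 10 percentage points higher from compound 2 to compound 3 (within the scatter) and also a number 9 percentage points higher from compound 1 to compound 3 (within the scatter) on the shared core. The three sulfur-bearing groups tested at this place therefore stay within the scatter of one another, and this change has not yet produced a difference that can be separated from it. No measurement at hand offers an explanation for these readings.

On these data alone, whether an amine, a carboxylic acid or a longer chain in place of methylsulfonyl would give a reading beyond the scatter remains open. Also open, as far as these compounds go, is how these compounds would compare as to potency, since the read-out comes from a single concentration and does not report it.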